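The source may report more compounds than this note shows. Statements on the series, on what has been measured and on what is new or still open speak of the compounds shown alone.

Of the compounds shown here, three have so far been tested in a functional assay on Caco-2 cells (Homo sapiens) for cytotoxicity, read by MTT assay, with stated times of 6 h and 48 h; a lower number here means a stronger inhibitor, a higher number a weaker inhibitor. Compound 1 `O=c1cc(-c2cc(Br)c(Br)[nH]2)oc2ccccc12` gives >= 100000 nM, which is a limit of the assay and not a number. Compound 2 `Cn1c(-c2cc(=O)c3ccccc3o2)cc(Br)c1Br` gives >= 100000 nM, also a limit. Compound 3 `Cn1c(-c2cc(-c3ccccc3O)no2)cc(Br)c1Br` gives >= 100000 nM, again only a limit. The change from compound 2 to compound 1 is hydrogen in place of methyl on an aromatic nitrogen, and its step in this assay is a step that the two limits leave unreadable from compound 2 to compound 1. Compound 4 `Oc1ccccc1-c1cc(-c2cc(Br)c(Br)[nH]2)on1` has not yet been measured; it differs from compound 3 by the same change, (hydrogen in place of methyl on an aromatic nitrogen), at a place described in identical words. How the core of compound 3 differs from that of compound 2 is not broken down here. Because (the limit of >= 100000 nM in this assay, at which 3 of the 3 values shown sit), the step of a number no higher from compound 3 to compound 4 (the limit leaves the size open) is expected to be small. Compound 4 is therefore estimated at 100000 nM, most likely reported once more as a limit.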

Compound 4, half-maximal inhibitory concentration: >= 100000 nM
Compound 4 gave a limit, no number (the forecaster's own chance of this, stated with the estimate: 85%); the middle value sits exactly at the limit.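

Compound 3 and compound 4 both gave only a limit of the assay, not a number, so no step can be read between them. The compounds shown leave open whether hydrogen in place of methyl on an aromatic nitrogen changes anything in this assay.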